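The source may hold more compounds than are shown below. What is called first, only, known or untested is meant among the compounds shown, and "the series" means these compounds.

Measured so far:
- compound 1, `CCN(Cc1cccs1)C(=O)c1cc2cc(C)ccc2o1`: 120 nM
- compound 2, `Cc1ccc(OCC(=O)N(Cc2cccs2)C2COC2)cc1`: 23000 nM
- compound 3, `CCN(Cc1ccncc1)C(=O)COc1ccc(C)cc1`: "not active" (no number reported)

In an assay on HEK293 cells for agonist activity at transient receptor potential cation channel subfamily M member 8 (Homo sapiens), read by fluorescence and calcium flux, with a stated time of 15 min (a higher number here means that more compound is needed for the effect, a lower number that less compound is needed), compound 2 gives 23000 nM, the highest of the two numbers reported. Compound 1, with a different core and an ethyl group on the amide nitrogen, gives 120 nM in this assay, a far lower number and well beyond the scatter. Compound 3 is reported as "not active" (no number reported) in this assay, with no number attached, so it offers no point of comparison in size. No pair among these three differs in one place, so no single step can be read from the measured set.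

Compound 4, `Cc1ccc(OCC(=O)N(Cc2cccs2)c2c[nH]nc2C)cc1`, differs from compound 2 in one place: 3-methyl-1H-pyrazol-4-yl in place of oxetan-3-yl on an amide-type nitrogen. The change keeps the shared core, the thienylmethyl arm and the amide intact. Nothing measured here isolates the effect of the group on the amide nitrogen, so the direction is open. A step within the scatter or a modest move in either direction is expected, with the estimate for compound 4 placed at 9000 nM (range 1500 nM to 45000 nM), which would mean a step of a 2.6-fold lower number from compound 2 to compound 4 (0.41 log units; beyond the scatter) in this assay.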

Compound 4, half-maximal effective concentration: 0.4 nM
The estimate for compound 4 lay 23000-fold (4.35 log units) above the measured number, outside the stated range (below it).
By their numbers in this assay, from the lowest: compound 4; then compound 1; then compound 2.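

In this assay the group on an amide-type nitrogen proves decisive: with the shared core, the thienylmethyl arm and the amide unchanged, 3-methyl-1H-pyrazol-4-yl in place of oxetan-3-yl gives a very large step (a 58000-fold lower number from compound 2 to compound 4 (4.76 log units; beyond the scatter)). Going by these compounds alone, the earlier compounds offered no single-place pair, so this is the first evidence that this position alone can carry a change of this size. The change replaces a four-membered non-aromatic ring with a five-membered aromatic ring and adds a hydrogen-bond donor, but no measurement shown explains the step.

Still open, from the compounds shown here alone, is which part of the new group carries the step: the methyl group, the pyrazole hydrogen on nitrogen or the aromatic ring itself. A 1H-pyrazol-4-yl group without the methyl, or a phenyl ring at this place, would help separate these features.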